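Methyl entering the bicyclic core of compound 3

A few compounds are considered here, and "the series" means these few. Any claim that something is new, unique, unknown or untested is made for them only; others in the source may bear on it.

Three compounds of the series carry numbers in an assay on OCI-Ly3 cells for activation of NF-kappa-B inhibitor alpha (Homo sapiens), read by a luciferase reporter; a higher number here means that more compound is needed for the effect, a lower number that less compound is needed. Compound 1 `Cc1ccc2cccc(NS(=O)(=O)c3ccccc3[N+](=O)[O-])c2n1` gives 8000 nM. Within the data shown here, compound 2 `Cc1ccc2cccc(NS(=O)(=O)c3ccc(C(F)(F)F)cc3[N+](=O)[O-])c2n1` gives 3600 nM, and the only single-place step among the measured compounds is a 2.2-fold lower number from compound 1 to compound 2 (0.35 log units; beyond the scatter). Compound 3 `COc1cc(NS(=O)(=O)c2ccc(C)cc2[N+](=O)[O-])c2ncccc2c1` gives 7600 nM. Compound 3 therefore holds the second highest of the three numbers: compound 1 lies within the scatter of it, while compound 2 lies lower by a margin beyond the scatter.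

Compound 4 `COc1cc(NS(=O)(=O)c2ccc(C)cc2[N+](=O)[O-])c2nc(C)ccc2c1` remains to be measured. It differs from compound 3 by methyl in place of hydrogen on an aromatic carbon. Among the measured compounds shown here, no measured step bears on this change: the one step in hand concerns a trifluoromethyl group on a different part of the molecule and says nothing about a methyl entering here. Compound 1 does carry a methyl on its core, but it differs from compound 3 in more than one place, and the two values of compound 1 and compound 3 merely sit within the scatter of each other. With nothing pointing either way, the expected step is a 1.1-fold lower number from compound 3 to compound 4 (0.04 log units; within the scatter), that is, none beyond the scatter. Compound 4 is accordingly estimated at 7000 nM, with a range from 3000 nM to 18000 nM.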

Compound 4, half-maximal effective concentration: > 57000 nM
Compound 4: no number, only a limit (the forecaster's own chance of this, stated with the estimate: 5%); middle value at least 8.1-fold (0.91 log units) away from the limit.
By their numbers in this assay, from the lowest: compound 2; then compounds 3 and 1 (each within the scatter of the next). At a limit, above all of these: compound 4.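

In this assay, among these compounds, compound 4 stands at > 57000 nM, which is a limit of the assay and not a number, and the only such limit so far: the limit of > 57000 nM in this assay, at which 1 of the 4 values shown sits. On the core of compound 3, methyl in place of hydrogen on this aromatic carbon, next to the ring nitrogen, gives an at least 7.5-fold higher number from compound 3 to compound 4 (0.87 log units; beyond the scatter), so a single added carbon at this position is enough to push the compound out of the measurable range of this assay. Among the compounds shown here, until now the only single-place step lay on a different part of the molecule, a 2.2-fold lower number from compound 1 to compound 2 (0.35 log units; beyond the scatter), and pointed to a lower number; this is the first single-place step on the core, and it points the other way and is larger.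

The true size of the step remains unknown, since the limit gives only its lower bound, and nothing shown says why this methyl has such an effect. Going by these compounds, whether fluorine, an amine or a longer chain on this same carbon would also end at a limit stays open, as does whether the step would hold on a core without the methoxy group.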